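The compounds below may be only part of what the source reports. "The series", "measured", "known", "first", "only" and "open" are said of these compounds alone.

Working notes: in a physicochemical assay for lipophilicity, at pH 7.4 (a higher number here means a more lipophilic compound, a lower number a more polar compound), compound 3 `CNC(=O)c1cc(C(=O)NC2CC2)cn(Cc2cccc3[nH]ncc23)c1=O` gives 1.5, within the scatter of compound 1 `CNC(=O)c1cc(C(=O)NC2CC2)cn(Cc2nccc3[nH]ccc23)c1=O` at 1.7, while compound 2 `CNC(=O)c1cc(C(=O)NC2CC2)cn(Cc2cccc(C)c2)c1=O` stands well apart at 3.6. Compound 4 `CNC(=O)c1cc(C(=O)NC2CC2)cn(Cc2ccc3nc[nH]c3c2)c1=O` carries 1H-benzimidazol-6-yl in place of 1H-indazol-4-yl on a saturated chain carbon bound to an aromatic nitrogen, with the same atoms joined differently. Among the measured compounds shown here, the nearest precedent is a number 0.20 log units lower from compound 1 to compound 3 (within the scatter), a swap that kept the heavy-atom count and stayed within the scatter. The large steps, a number 1.90 log units higher from compound 1 to compound 2 (beyond the scatter) and a number 2.10 log units lower from compound 2 to compound 3 (beyond the scatter), both involve 3-methylphenyl, which plays no part here. No shift beyond the scatter is therefore expected in this assay. The expected step is a number 0.20 log units lower from compound 3 to compound 4 (within the scatter). For compound 4 the estimated value is 1.3, with an expected range of 0.9 to 1.7.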

Compound 4, distribution coefficient: 1.2
Beside the measured number, compound 4's estimate is 0.10 log units above it; measured number inside the range.
By their numbers in this assay, from the lowest: compounds 4, 3 and 1 (each within the scatter of the next, the first and the last beyond it); then compound 2.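

On a saturated chain carbon bound to an aromatic nitrogen, this assay does not separate 1H-benzimidazol-6-yl from 1H-indazol-4-yl, the step being a number 0.30 log units lower from compound 3 to compound 4 (within the scatter). Among the three groups with the same heavy-atom count, the only step beyond the scatter is a number 0.50 log units lower from compound 1 to compound 4 (beyond the scatter), while replacing 3-methylphenyl gives a number 2.40 log units lower from compound 2 to compound 4 (beyond the scatter), the widest step in the set. Nothing available explains these differences.

On these data alone, whether a carboxylic acid or an amine in place of the methyl of 3-methylphenyl would reach the range of compound 1, compound 3 and compound 4 stays open.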